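This account rests on a few compounds, and the source may have more. Where it says the series, first, only, none or still open, it means among the compounds named here.

- Compound 1 `COc1ccc(C2=C(c3cc(OC)c(OC)c(OC)c3)C(=O)CC2C)cc1C(=O)O`: > 100 ug/mL, a limit of the assay
- Compound 2 `COc1ccc(OC)c(C2=C(c3cc(OC)c(OC)c(OC)c3)C(=O)CC2O[SiH2]C(C)(C)C)c1`: 6.5 ug/mL
- Compound 3 `COc1ccc(OC)c(C2=C(c3cc(OC)c(OC)c(OC)c3)C(=O)CC2O)c1`: > 100 ug/mL, a limit of the assay

Within the data shown here, in an ADME assay on ECV-304 cells (Homo sapiens) for cytotoxicity, read by MTT assay, with a stated time of 72 h (a higher number here means a weaker inhibitor, a lower number a stronger inhibitor), compound 2 gives 6.5 ug/mL, the only actual number among the three. The values of compound 1 and compound 3 are limits of the assay. Compound 4 `COc1ccc(C2=C(c3cc(OC)c(OC)c(OC)c3)C(=O)CC2O[SiH2]C(C)(C)C)cc1O` differs from compound 2 at one place: 3-hydroxy-4-methoxyphenyl in place of 2,5-dimethoxyphenyl on a double-bonded ring carbon. Among the measured compounds shown here, the only measured step, an at least 15-fold higher number from compound 2 to compound 3 (1.18 log units; beyond the scatter), is large and beyond the scatter. It lies at the oxygen on a saturated carbon, however, and compound 4 keeps that group unchanged. For the measured compounds named here, no measured step covers the change on the double-bonded ring carbon, so the size of the step cannot be read from the data. With the group retained, compound 4 is expected to stay measurable, not to fall to a limit, with a modest move toward a lower number and wide uncertainty. The expected change is a 3.3-fold lower number from compound 2 to compound 4 (0.51 log units; beyond the scatter). For compound 4 the estimated value is 2 ug/mL, with an expected range from 0.1 ug/mL to 15 ug/mL.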

Compound 4, half-maximal inhibitory concentration: 30 ug/mL
Beside the measured number, compound 4's estimate is 15-fold (1.18 log units) below it, and the stated range ends below it.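

Replacing 2,5-dimethoxyphenyl with 3-hydroxy-4-methoxyphenyl on the double-bonded ring carbon gives a 4.6-fold higher number from compound 2 to compound 4 (0.66 log units; beyond the scatter), so the number in this assay responds to this position as well as to the group on the oxygen on a saturated carbon. The step is modest and runs toward a higher number, although the new group brings one hydrogen-bond donor and one fewer heavy atom. With the group on the oxygen kept, compound 4 still gives a measured number and does not reach a limit of the assay: the limit of > 100 ug/mL in this assay, at which 2 of the 4 values shown sit.

The swap moves the methoxy groups and adds the hydroxyl in a single step, so the compounds shown cannot separate these two changes. On these data alone, how an amine or a carboxylic acid in place of that hydroxyl would read here remains open.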